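The compounds below may be only part of what the source reports. "The series", "measured", "known", "first", "only" and "open" are said of these compounds alone.

Compound 1 `Cc1nc(-c2cnc3ccc(-c4ccc(N)cc4)cc3c2)no1` and compound 2 `CC(C)c1nc(-c2cnc3ccc(-c4ccc(N)cc4)cc3c2)no1` share one core and differ in a functional assay on RD cells (Homo sapiens) for inhibition, read by luminescence and ATP content, with a stated time of 72 h (a lower number here means that less compound is tolerated, a higher number that more compound is tolerated), by a step that the two limits leave unreadable from compound 1 to compound 2. For compound 1 this assay gives only a limit, > 2500 nM. For compound 2 it gives only a limit, > 800 nM. Compound 3 `CCCCc1nc(-c2cnc3ccc(-c4ccc(N)cc4)cc3c2)no1` carries butyl in place of isopropyl on an aromatic carbon. Among the measured compounds shown here, the single measured step is left unreadable by the two limits the limit of > 2500 nM in this assay, at which 1 of the 2 values shown sits, and (the limit of > 800 nM in this assay, at which 1 of the 2 values shown sits), so neither its size nor its direction in this assay can be drawn on. Compound 3 is therefore expected to give 2500 nM, with a range from 700 nM to 10000 nM. The step this estimate implies, a step that the limit leaves unreadable from compound 2 to compound 3, is an expectation and not a reading.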

Compound 3, half-maximal cytotoxic concentration: > 2500 nM
Compound 3: no number, only a limit (the forecaster's own chance of this, stated with the estimate: 70%); the middle value sits exactly at the limit.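

Among the compounds shown here, compound 1, compound 2 and compound 3 each give only a limit in this assay, and no step among them can be read. The compounds shown leave open whether exchanging methyl, isopropyl and butyl changes the half-maximal cytotoxic concentration at all.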